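Working notes: step from compound 2 to compound 3

The compounds below may be only part of what the source reports. "The series", "measured", "known", "first", "only" and "open" are said of these compounds alone.

Measured so far:
- compound 1, `CCC1([C@@H](O)C/C=C/[C@H]2[C@H](O)CC(=O)[C@@H]2C/C=C\CCCC(=O)O)CCC1`: in an assay on CHO cells for binding affinity to prostacyclin receptor (Homo sapiens) (a lower number here means a stronger inhibitor, a higher number a weaker inhibitor), compound 1 gives > 10000 nM, a limit of the assay and not a number.
- compound 2, `CCCCCC1([C@@H](O)C/C=C/[C@H]2[C@H](O)CC(=O)[C@@H]2C/C=C\CCCC(=O)O)CCC1`: in this assay compound 2 gives > 10000 nM, again a limit and not a number.

Both values sit at the limit, so the step that the two limits leave unreadable from compound 1 to compound 2 cannot be read. Where compound 2 stands is known only through (the limit of > 10000 nM in this assay, at which 2 of the 2 values shown sit); it is somewhere beyond that limit, with no number attached.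

Compound 3, `CC(C)CC1([C@@H](O)C/C=C/[C@H]2[C@H](O)CC(=O)[C@@H]2C/C=C\CCCC(=O)O)CCC1`, differs from compound 2 by isopropyl in place of butyl on a saturated chain carbon bound to a saturated ring carbon. For the measured compounds named here, no measured step bears on this change, and the only step that is known at all is itself unreadable. The expected step that the limit leaves unreadable from compound 2 to compound 3 is therefore not placed beyond the scatter in either direction. In this assay compound 3 is estimated at 20000 nM, with a range from 4000 nM to 100000 nM, and is expected most likely to be reported once more only as a limit.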

Compound 3, inhibition constant: > 10000 nM
Compound 3 ended at the assay's limit (the forecaster's own chance of this, stated with the estimate: 85%); the middle value does not contradict the limit.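

In this assay compound 3 gives > 10000 nM, a limit of the assay and not a number. For the compounds shown here, no step among compound 1, compound 2 and compound 3 can be read: the limit of > 10000 nM in this assay, at which 3 of the 3 values shown sit. The compounds shown leave open how strongly any of the three binds and whether the chain on the shared core affects binding at all.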